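Halogen swap on the N-aryl ring of the shared core

A few compounds are considered here, and "the series" means these few. Any claim that something is new, unique, unknown or untested is made for them only; others in the source may bear on it.

Measured compounds:
- compound 1 `CCNC(=O)c1cc(Oc2ccc(NC(=O)c3cc4cccnc4n(-c4ccccc4F)c3=O)cc2)ccn1`: 490 nM
- compound 2 `CCNC(=O)c1cc(Oc2ccc(NC(=O)c3cc4cccnc4n(-c4ccc(F)cc4)c3=O)cc2)ccn1`: 120 nM

Both were run in a functional assay on A549 cells (Homo sapiens) for antiproliferative activity, read by MTT assay, with a stated time of 72 h; a higher number here means a weaker inhibitor, a lower number a stronger inhibitor. Within the data shown here, compound 2 stands at the lower of the two numbers; its nearest neighbour is compound 1, and the step of a 4.1-fold lower number from compound 1 to compound 2 (0.61 log units; beyond the scatter) is the only comparison in hand.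

Compound 3 `CCNC(=O)c1cc(Oc2ccc(NC(=O)c3cc4cccnc4n(-c4ccc(Cl)cc4)c3=O)cc2)ccn1` has not yet been measured. Its difference from compound 2 is chloro in place of fluoro on an aromatic carbon; cut one bond further out, this reads as 4-fluorophenyl to 4-chlorophenyl on the nitrogen of the shared core. Among the measured compounds shown here, no measured step concerns a chloro-for-fluoro exchange: the single known step, a 4.1-fold lower number from compound 1 to compound 2 (0.61 log units; beyond the scatter), moved the fluorine from one ring position to another and does not speak to the halogen identity. With nothing directly bearing on it, the expected step in this assay is none beyond the scatter, in either direction, giving the estimated 1.1-fold lower number from compound 2 to compound 3 (0.04 log units; within the scatter). For compound 3 the estimate is therefore 110 nM, with a range from 40 nM to 350 nM, the range kept wide for want of a precedent.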

Compound 3, half-maximal inhibitory concentration: 250 nM
Compound 3: middle estimate off by 2.3-fold (0.36 log units), on the low side, and the stated range covers the measured number.
By their numbers in this assay, from the lowest: compound 2; then compounds 3 and 1 (each within the scatter of the next).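

In this assay, the identity of the halogen now has a reading of its own: the change from 4-fluorophenyl to 4-chlorophenyl gives a 2.1-fold higher number from compound 2 to compound 3 (0.32 log units; beyond the scatter) and so is a modest step, which the earlier fluorine shift could not show. Against the 2-fluorophenyl group, 4-chlorophenyl gives a 2.0-fold lower number from compound 1 to compound 3 (0.29 log units; within the scatter) and does not separate from it, so the advantage of compound 2 does not extend to the chloro analogue. Among these compounds, compound 2 is thus the only member of these three with steps beyond the scatter to both others, though the data do not say what sets fluoro apart from chloro at this position.

Still open, going by these compounds, is how the position responds to groups other than these two halogens, such as bromo, methoxy, an amine or a carboxylic acid in place of the fluoro of compound 2. Also open, on these data alone, is whether 2-chlorophenyl would stand to 4-chlorophenyl as 2-fluorophenyl stands to 4-fluorophenyl, which would show whether the effect of ring position holds across halogens.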